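The source may report more compounds than this note shows. Statements on the series, on what has been measured and on what is new or still open speak of the compounds shown alone.

Within the data shown here, in an ADME assay on cells (Hepatocyte, Rattus norvegicus) for pharmacokinetics, read by LC-MS, with a stated time of 90 min, tested at 1 uM (on this read-out higher numbers stand for fast clearance and lower numbers for slow clearance), three compounds on one shared core have numbers so far. Compound 1 `CCN(C(=O)OC)c1c(N)nc(-c2nn(Cc3ccccc3F)c3ncccc23)nc1N` gives 11.7 mL/min/kg and compound 2 `CC(C)OC(=O)Nc1c(N)nc(-c2nn(Cc3ccccc3F)c3ncccc23)nc1N` gives 15 mL/min/kg on this read-out. Compound 3 `Nc1nc(-c2nn(Cc3ccccc3F)c3ncccc23)nc(N)c1NC(=O)OC1COC1` gives 1.67 mL/min/kg and holds the lowest of the three numbers, with both others beyond the scatter from it. Compound 4 `Nc1nc(-c2nn(Cc3ccccc3F)c3ncccc23)nc(N)c1NC(=O)OCC(F)(F)F` is still unmeasured and differs from compound 3 at one place only. The change 2,2,2-trifluoroethyl in place of oxetan-3-yl on an oxygen next to a carbonyl group puts 2,2,2-trifluoroethyl in place of oxetan-3-yl on an oxygen next to a carbonyl group. The step that bears most directly is a 9.0-fold lower number from compound 2 to compound 3 (0.95 log units; beyond the scatter) and it is an exchange at that same place, with isopropyl leaving and oxetan-3-yl entering. The step of a 7.0-fold lower number from compound 1 to compound 3 (0.85 log units; beyond the scatter) is of similar size, whereas a 1.3-fold higher number from compound 1 to compound 2 (0.11 log units; within the scatter) stays within the scatter. Among the measured compounds shown here, no measured compound carries 2,2,2-trifluoroethyl, so the size remains uncertain. Going by compound 2 at 15 mL/min/kg on this read-out, a move back toward higher numbers is expected in this assay once oxetan-3-yl leaves, though probably not the whole way. The estimated step is a 3.6-fold higher number from compound 3 to compound 4 (0.56 log units; beyond the scatter) in the direction of faster clearance. For compound 4 the estimated value is 6 mL/min/kg with an expected range from 2.2 mL/min/kg to 16 mL/min/kg on this read-out.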

Compound 4, clearance: 35 mL/min/kg
The estimate for compound 4 lay 5.8-fold (0.77 log units) below the measured number, outside the stated range (above it).
By their numbers in this assay, from the lowest: compound 3; then compounds 1 and 2 (each within the scatter of the next); then compound 4.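

Replacing oxetan-3-yl with 2,2,2-trifluoroethyl at this position on the oxygen next to a carbonyl group gives a 21-fold higher number from compound 3 to compound 4 (1.32 log units; beyond the scatter) in this assay, so the earlier contrast between oxetan-3-yl and isopropyl did not mark the upper end of what this position can show. The change from isopropyl to 2,2,2-trifluoroethyl gives a 2.3-fold higher number from compound 2 to compound 4 (0.37 log units; beyond the scatter), and the comparison with the ethyl(methoxycarbonyl)amino group gives a 3.0-fold higher number from compound 1 to compound 4 (0.48 log units; beyond the scatter), so compound 4 now stands apart from compounds 1 and 2, whose own numbers lie within the scatter of each other. No measurement shown here accounts for the differences among these groups.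

The compounds shown leave open whether the high number belongs to the three fluorines or to the open chain itself, a question that a plain ethyl group on the same oxygen would address directly. They also leave open whether the low number of compound 3 is particular to oxetan-3-yl or extends to other rings on that oxygen, such as tetrahydrofuran-3-yl or cyclobutyl, which would show how far it carries.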